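Exchanging aminocarbamoyl for hydroxymethyl: expected cytotoxicity

A few compounds are considered here, and "the series" means these few. Any claim that something is new, unique, unknown or untested is made for them only; others in the source may bear on it.

Of the compounds shown here, three have been tested in an ADME assay on TZM cells (Homo sapiens) for cytotoxicity, read by XTT assay, with a stated time of 4 days; on this read-out higher numbers stand for lower toxicity in this test and lower numbers for higher toxicity in this test. Compound 1, `COC(=O)c1cc(N)c(Nc2ccc(C#N)cc2)cc1Oc1c(C)cc(/C=C/C#N)cc1C`, gives > 22800 nM, which is a limit of the assay rather than a number. Compound 2, `Cc1cc(CCC#N)cc(C)c1Oc1cc(Nc2ccc(C#N)cc2)c(N)cc1S(N)(=O)=O`, gives 11100 nM. Compound 3, `Cc1cc(CCC#N)cc(C)c1Oc1cc(Nc2ccc(C#N)cc2)c(N)cc1C(=O)NN`, gives > 22700 nM, again a limit and not a number. For the measured compounds named here, the only step between measured compounds that differ in one place is an at least 2.0-fold higher number from compound 2 to compound 3 (0.31 log units; beyond the scatter), and it is the sole measured guide to exchanges at this position. Compound 3 thus stands at a limit of this assay; the limit of > 22700 nM in this assay, at which 1 of the 3 values shown sits, holds its value, and the limit of > 22800 nM in this assay, at which 1 of the 3 values shown sits, shows that one other of the three values is also a limit, so no number separates the two.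

Compound 4 is `Cc1cc(CCC#N)cc(C)c1Oc1cc(Nc2ccc(C#N)cc2)c(N)cc1CO`. It differs from compound 3 by hydroxymethyl in place of aminocarbamoyl on an aromatic carbon. Going by the values given here, no measured step covers this exact exchange. The step from compound 2 to compound 3 at this position was only modest, so for compound 4 the expectation in this assay is a step of no more than modest size in either direction, most probably a value again at or near the limit. Compound 4 is therefore expected to give 22000 nM, within the range 9000 nM to 50000 nM. The step this estimate implies, an at least 1.0-fold lower number from compound 3 to compound 4 (0.01 log units; that floor lies within the scatter), is expected to be small.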

Compound 4, half-maximal cytotoxic concentration: > 23800 nM
Compound 4: no number, only a limit (the forecaster's own chance of this, stated with the estimate: 60%); middle value at least 1.0-fold (0.03 log units) from the limit.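

In this assay compound 4 gives > 23800 nM, which is a limit of the assay and not a number. Hydroxymethyl in place of sulfamoyl gives an at least 2.1-fold higher number from compound 2 to compound 4 (0.33 log units; beyond the scatter), so aminocarbamoyl is no longer the only group at this position on the aromatic carbon that stands clear of sulfamoyl, and a group with fewer heavy atoms and no carbonyl does so as well. The exchange of aminocarbamoyl for hydroxymethyl itself cannot be read, with a limit on each side of it, and the new limit is the one that compound 4 adds: the limit of > 23800 nM in this assay, at which 1 of the 4 values shown sits.

Among the compounds that differ at this position, sulfamoyl alone carries a number, so how far the other two groups lie from it, and whether they differ from each other, stays unknown. Also open, going by these compounds, is whether a carboxylic acid, a primary amine or a longer chain such as hydroxyethyl at this position would stay at a limit in this assay or give a number, as compound 2 does.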